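Second chloro on the aryl ring of compound 1

A few compounds are considered here, and "the series" means these few. Any claim that something is new, unique, unknown or untested is made for them only; others in the source may bear on it.

In an assay on HEK293 cells for displacement of a labelled ligand from 5-hydroxytryptamine receptor 7 (Rattus norvegicus), read by radioligand binding (a lower number here means a stronger inhibitor, a higher number a weaker inhibitor), compound 1 `CC(C)n1nc2c(c1-c1ccc(Cl)cc1)CCNCC2` gives 9 nM, the lowest of the two numbers to hand. Its nearest neighbour is compound 2 `CC(C)n1nc2c(c1-c1ccc(C(F)(F)F)cc1)CCNCC2`, which gives 15 nM; the step of a 1.7-fold higher number from compound 1 to compound 2 (0.22 log units; within the scatter). Compound 3 `CC(C)n1nc2c(c1-c1ccc(Cl)cc1Cl)CCNCC2` differs from compound 1 by chloro in place of hydrogen on an aromatic carbon. For the measured compounds named here, no measured step covers this change; the only step on the same ring, a 1.7-fold higher number from compound 1 to compound 2 (0.22 log units; within the scatter), did not leave the scatter, so no step beyond the scatter is expected in this assay, in either direction. The expected step is therefore a 1.1-fold higher number from compound 1 to compound 3 (0.05 log units; within the scatter). Compound 3 is estimated at 10 nM, within 4 nM to 25 nM.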

Compound 3, inhibition constant: 400 nM
Estimate against measurement, compound 3: 40-fold (1.60 log units) below; measured number outside the range, above it.
By their numbers in this assay, from the lowest: compounds 1 and 2 (each within the scatter of the next); then compound 3.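

In this assay, the aromatic carbon ortho to a large group is far less forgiving than the earlier comparison suggested: adding chloro here gives a 44-fold higher number from compound 1 to compound 3 (1.65 log units; beyond the scatter), whereas replacing chloro with trifluoromethyl elsewhere on the ring gave a 1.7-fold higher number from compound 1 to compound 2 (0.22 log units; within the scatter). One added chlorine atom is therefore enough to leave the scatter. Nothing at hand gives a reason for this step. Still open, going by these compounds, is whether fluoro, methyl or methoxy at this carbon gives a step of similar size, and whether a lone chloro here, without the chloro group meta to it, does the same.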